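The source may report more compounds than this note shows. Statements on the series, on what has been measured and on what is new or still open speak of the compounds shown alone.

Series of sulfonamides with a shared core, followed in an assay on isolated protein for binding affinity to secreted frizzled-related protein 1 (Homo sapiens), read by fluorescence; on this read-out lower numbers stand for stronger inhibition and higher numbers for weaker inhibition. Compound 1 `O=C(CN1CCNCC1)N1CCC(NS(=O)(=O)c2cc(S(=O)(=O)c3ccccc3)ccc2C(F)(F)F)CC1` carries a piperazinylacetyl group on the piperidine nitrogen; in this assay compound 1 gives 140 nM. Compound 2 `CN(C)c1ccc(C(=O)N2CCC[C@H]2C(=O)N2CCC(NS(=O)(=O)c3cc(S(=O)(=O)c4ccccc4)ccc3C(F)(F)F)CC2)cc1` carries instead a prolyl unit capped with a (4-(dimethylamino)phenyl)carbonyl group; in this assay compound 2 gives 110 nM. Compound 2 stands at the lower of the two numbers, but its gap to compound 1 lies within the scatter, so the two read as equivalent.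

Compound 3 `CCNC(=O)N1CCC[C@H]1C(=O)N1CCC(NS(=O)(=O)c2cc(S(=O)(=O)c3ccccc3)ccc2C(F)(F)F)CC1` is the next member: ethylamino in place of 4-(dimethylamino)phenyl on a carbonyl carbon. Among the measured compounds shown here, no measured pair shows the effect of such a change. Since compound 1 and compound 2 differ widely in this region yet sit at similar numbers, the step of a 1.4-fold higher number from compound 2 to compound 3 (0.13 log units; within the scatter) is expected to be small, with no direction beyond the scatter. Compound 3 is expected near 150 nM, with a range from 60 nM to 400 nM.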

Compound 3, half-maximal inhibitory concentration: 30 nM
Compound 3: middle estimate off by 5.0-fold (0.70 log units), on the high side; the measured number lies below the stated range.
By their numbers in this assay, from the lowest: compound 3; then compounds 2 and 1 (each within the scatter of the next).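

In this assay the group on this carbonyl carbon now proves to matter: ethylamino in place of 4-(dimethylamino)phenyl gives a 3.7-fold lower number from compound 2 to compound 3 (0.56 log units; beyond the scatter), a separation that compound 1 and compound 2 did not show. The replacement of (piperazin-1-yl)methyl by 1-(ethylcarbamoyl)pyrrolidin-2-yl gives a 4.7-fold lower number from compound 1 to compound 3 (0.67 log units; beyond the scatter), so compound 3 stands apart from both earlier compounds, and the six-membered aromatic ring of compound 2 is not required for a low number in this series. Nothing measured on hand accounts for the step.

The step from compound 2 to compound 3 removes the aromatic ring and adds the amide hydrogen together, so the compounds shown do not separate the two changes. Dimethylamino or phenylamino on the same carbonyl carbon would pull them apart, and propylamino would test whether the ethyl chain can be lengthened.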